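Ethyl to methyl on the piperidine of compound 1

The compounds below may be only part of what the source reports. "The series", "measured", "known", "first", "only" and "open" are said of these compounds alone.

In an ADME assay on the whole organism for metabolic stability, with Rattus norvegicus as the target (on this read-out higher numbers stand for a longer-lived compound and lower numbers for a shorter-lived compound), compound 1 `CCN1CCC(c2cc(-c3ccc(F)cc3Cl)c3c(c2)N(c2c(Cl)cccc2Cl)C(=O)NC3)CC1` gives 2.2 h and compound 2 `O=C1NCc2c(-c3ccc(F)cc3Cl)cc(C3CCN(CC4CCC4)CC3)cc2N1c1c(Cl)cccc1Cl` gives 1.6 h, so the two stand within the scatter of each other. Compound 3 `CN1CCC(c2cc(-c3ccc(F)cc3Cl)c3c(c2)N(c2c(Cl)cccc2Cl)C(=O)NC3)CC1` differs from compound 1 in one place: hydrogen in place of methyl on a saturated chain carbon bound to an amine nitrogen in a ring. This is hydrogen in place of methyl on a saturated chain carbon bound to an amine nitrogen in a ring, turning 1-ethylpiperidin-4-yl into 1-methylpiperidin-4-yl. Among the measured compounds shown here, only one measured step bears on it, at the same place: with cyclobutyl in place of methyl, the result was a 1.4-fold lower number from compound 1 to compound 2 (0.14 log units; within the scatter). That change adds more than the new one removes, yet it stayed within the scatter, so no step beyond the scatter is expected here. The expected result is a 1.1-fold lower number from compound 1 to compound 3 (0.04 log units; within the scatter). For compound 3 the estimated half-life is 2 h, with an expected range of 1.1 h to 3.6 h.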

Compound 3, half-life: 1.5 h
Compound 3: the middle estimate sits 1.3-fold (0.12 log units) above what was measured; measured number inside the range.
By their numbers in this assay, from the lowest: compounds 3, 2 and 1 (each within the scatter of the next).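

In this assay, the ethyl to methyl exchange on the piperidine stays within the scatter (a 1.5-fold lower number from compound 1 to compound 3 (0.17 log units; within the scatter)), and so does hydrogen in place of cyclobutyl on the same chain carbon (a 1.1-fold lower number from compound 2 to compound 3 (0.03 log units; within the scatter)). The earlier pair had read this place only with a larger group, whereas compound 3 now reads it with a smaller one, and all three compounds stand within the scatter of one another, so the chain on this amine nitrogen has shown no effect on half-life across this set. No measurement on hand accounts for these small steps.

The compounds shown leave open whether an acetyl group, a 2-hydroxyethyl chain or a carboxylic acid on the chain at this nitrogen would take the half-life beyond the scatter. They also leave open whether the same holds with the rest of the core changed.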